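Chloro in Place of Methyl: An Expected Shift

The source may hold more compounds than are shown below. What is called first, only, known or untested is meant among the compounds shown, and "the series" means these compounds.

In a physicochemical assay for acid dissociation, using potentiometric titration, compound 2 (`CCC/N=C1\S/C(=C\c2ccc(O)c(C)c2)C(=O)N1c1ccccc1C`) gives 8.5 and compound 1 (`CCC/N=C1\S/C(=C\c2ccc(O)c(C(C)C)c2)C(=O)N1c1ccccc1C`) gives 8.6, so the two values lie within the scatter of each other. Going by the values given here, the only measured step so far is a number 0.10 log units lower from compound 1 to compound 2 (within the scatter).

The next compound, compound 3 (`CCC/N=C1\S/C(=C\c2ccc(O)c(Cl)c2)C(=O)N1c1ccccc1C`), carries chloro in place of the methyl of compound 2, on an aromatic carbon, ortho to a hydroxy group and meta to a large group: chloro in place of methyl on an aromatic carbon.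

The measured step bears on this change only in part. It swaps isopropyl for methyl, two groups built from carbon and hydrogen alone, whereas chloro brings in a different element. Among the compounds with values here, no measured compound here carries chloro, so that small step cannot simply be carried over, and the range has to stay wide.

A shift beyond the scatter, towards a lower number, is expected, and the estimated step is a number 1.30 log units lower from compound 2 to compound 3 (beyond the scatter). For compound 3 the expected value is 7.2, with an estimated range from 6.6 to 7.8.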

Compound 3, acid dissociation constant: 6.8
Compound 3: the middle estimate sits 0.40 log units above what was measured, and the stated range covers the measured number.
By their numbers in this assay, from the lowest: compound 3; then compounds 2 and 1 (each within the scatter of the next).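

In this assay this position turns out to be far from indifferent to what sits on it: chloro in place of methyl gives a number 1.70 log units lower from compound 2 to compound 3 (beyond the scatter) and chloro in place of isopropyl gives a number 1.80 log units lower from compound 1 to compound 3 (beyond the scatter) as a comparable result. Going by these compounds alone, the earlier pair showed only that one carbon-and-hydrogen group can replace another here without a change beyond the scatter, as a number 0.10 log units lower from compound 1 to compound 2 (within the scatter) makes plain, so swapping the element attached to this aromatic carbon is what first moves the number by a large amount in this small set. No measurement shown here explains why chloro has this result, so the size of the shift stands as an observation only.

One chloro compound cannot show whether the shift is particular to chloro, and fluoro, bromo, a nitrile or an amine at this position could each give a smaller, similar or larger step. From the compounds shown here alone, it also remains open whether chloro would shift the number as far at another place on the six-membered aromatic ring.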